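The source may hold more compounds than are shown below. What is called first, only, known or untested is meant among the compounds shown, and "the series" means these compounds.

Measured compounds:
- Compound 1 `Cc1cc(/C=C/C#N)cc(C)c1Oc1cc(Nc2ccc(C#N)cc2)c(N)cc1C(N)=O`: > 23600 nM
- Compound 2 `Cc1cc(CCC#N)cc(C)c1Oc1cc(Nc2ccc(C#N)cc2)c(N)cc1C(F)(F)F`: > 7100 nM
- Compound 3 `Cc1cc(CCC#N)cc(C)c1Oc1cc(Nc2ccc(C#N)cc2)c(N)cc1C(N)=O`: > 9400 nM

In an ADME assay on TZM cells (Homo sapiens) for cytotoxicity, read by XTT assay, with a stated time of 4 days (on this read-out higher numbers stand for lower toxicity in this test and lower numbers for higher toxicity in this test), compound 1 gives > 23600 nM, which is a limit of the assay and not a number. Compounds 2 and 3 also give only limits, so the three cannot be ranked against one another.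

Compound 4 `CNC(=O)c1cc(N)c(Nc2ccc(C#N)cc2)cc1Oc1c(C)cc(/C=C/C#N)cc1C` has not yet been measured. It differs from compound 1 by methyl in place of hydrogen on an amide-type nitrogen.

For the measured compounds named here, two measured steps bear on this change only loosely. One is a step that the two limits leave unreadable from compound 2 to compound 3, which at least involves the carbamoyl group. The other is a step that the two limits leave unreadable from compound 1 to compound 3, which shows a change elsewhere on the molecule. Neither has a readable size, so neither gives grounds to expect a change in this assay.

The estimate therefore rests on compound 1, whose limit is > 23600 nM. No shift beyond the usual scatter is expected, and the estimated step is an at least 1.0-fold lower number from compound 1 to compound 4 (0.01 log units; that floor lies within the scatter). Compound 4 is expected at 23000 nM, with an estimated range of 8000 nM to 70000 nM.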

Compound 4, half-maximal cytotoxic concentration: > 9200 nM
Compound 4: a limit, no number; the forecaster's own chance of this, stated with the estimate: 70%; the middle value lies beyond the limit too.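

For the compounds shown here, compound 1 and compound 4 each give only a limit of the assay, not a number, so no step between them can be read. The compounds shown leave open whether methyl in place of hydrogen on the amide-type nitrogen changes the result in this assay at all.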